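Compound 2 to compound 4: what to expect

The source may hold more compounds than are shown below. What is called first, only, known or untested is meant among the compounds shown, and "the series" means these compounds.

Compound 1 `C=CC(=O)Nc1nc(-c2ccccc2)cs1`: 18600 nM
Compound 2 `C=CC(=O)N(CC(=O)OC(C)(C)C)c1nc(-c2ccccc2)cs1`: 20900 nM
Compound 3 `C=CC(=O)N(CC(=O)NC1CCCCC1)c1nc(-c2ccccc2)cs1`: >= 29300 nM

All three entries come from a functional assay on HCT-116 cells (Homo sapiens) for antiproliferative activity, read by MTT assay, with a stated time of 72 h; a lower number here means a stronger inhibitor, a higher number a weaker inhibitor. The entry for compound 3 is a limit of the assay and not a number. Compound 2 sits together with compound 1, as the measured step is a 1.1-fold higher number from compound 1 to compound 2 (0.05 log units; within the scatter), so these two cannot be told apart.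

The next compound is compound 4 `C=CC(=O)N(Cc1cc(C)no1)c1nc(-c2ccccc2)cs1`, and the change is 3-methyl-1,2-oxazol-5-yl in place of tert-butoxycarbonyl on a saturated chain carbon bound to an amide-type nitrogen. In words, this places 3-methyl-1,2-oxazol-5-yl in place of tert-butoxycarbonyl on a saturated chain carbon bound to an amide-type nitrogen. For the measured compounds named here, no measured compound carries this new group, so the guidance is only indirect.

Going by the values given here, two measured steps bear on it, since both involve the group on the amide-type nitrogen. The first is the step already given for compound 2 and compound 1. The second changes the far end of that group, and it is an at least 1.4-fold higher number from compound 2 to compound 3 (0.14 log units; that floor lies within the scatter). Neither step stands clear of the scatter, so no step beyond the scatter is expected here, and no direction can be favoured. The expected change in this assay is a 1.1-fold higher number from compound 2 to compound 4 (0.02 log units; within the scatter). For compound 4 the estimated value is 22000 nM, with an expected range of 10000 nM to 45000 nM.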

Compound 4, half-maximal inhibitory concentration: > 30000 nM
Compound 4 gave a limit, no number; the forecaster's own chance of this, stated with the estimate: 25%; middle value at least 1.3-fold (0.13 log units) from the limit.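

In this assay compound 4 stops at a limit of the assay, not a number: the limit of > 30000 nM in this assay, at which 1 of the 4 values shown sits. Replacing tert-butoxycarbonyl with an aromatic ring on this saturated chain carbon brings no measurable gain, since the change gives an at least 1.4-fold higher number from compound 2 to compound 4 (0.15 log units; that floor lies within the scatter), and the whole (3-methyl-1,2-oxazol-5-yl)methyl group in place of the hydrogen on the amide-type nitrogen gives an at least 1.6-fold higher number from compound 1 to compound 4 (0.20 log units; that floor lies within the scatter). Compound 3 also ends at a limit, so this ring and the cyclohexylamino end group both give no measured number here, and the two cannot be put in order: the limit of >= 29300 nM in this assay, at which 1 of the 4 values shown sits.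

How far the number truly rises remains unknown, and the compounds shown also leave open whether any group on this chain can give a number clearly lower than that of compound 1, which is 18600 nM. A free carboxylic acid or an amine at the end of the chain, a longer chain, or a plain phenyl ring in place of the 3-methyl-1,2-oxazol-5-yl group would each test this position in a different way.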